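The source may report more compounds than this note shows. Statements on the series, on what has been measured and on what is new or still open speak of the compounds shown alone.

Of the compounds shown here, two on the shared core have been measured in a functional assay on CCRF-CEM cells (Homo sapiens) for antiproliferative activity, read by MTT assay, with a stated time of 48 h, tested at 50 uM; on this read-out lower numbers stand for a stronger effect and higher numbers for a weaker effect at the one concentration tested. Compound 1 `OCC(O)Cn1nc2c(Br)c(Br)c(Br)c(Br)c2n1` gives 27%, the higher of the two numbers and so the weaker effect at the concentration used. Compound 2 `OC(CCn1nc2c(Br)c(Br)c(Br)c(Br)c2n1)c1ccccc1` gives 0%, a number lower than that of compound 1 by more than the scatter. Compound 3 `C[C@@H](O)CCn1nc2c(Br)c(Br)c(Br)c(Br)c2n1` has not been measured; it differs from compound 1 by 2-hydroxypropyl in place of 1,2-dihydroxyethyl on a saturated chain carbon bound to an aromatic nitrogen. Within the data shown here, no measured pair carries a change of this kind, so only a modest step is expected: a number 7 percentage points lower from compound 1 to compound 3 (within the scatter) is expected to be small, toward a lower number or none beyond the scatter. Compound 3 is estimated at 20%, within 5% to 40%.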

Compound 3, a percentage reported as activity, at one concentration (the size of the read-out at that concentration, not a potency): 23%
The estimate for compound 3 lay 3 percentage points below the measured number, within the range that was stated.
By their numbers in this assay, from the lowest: compound 2; then compounds 3 and 1 (each within the scatter of the next).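

In this assay, among these compounds, 2-hydroxypropyl in place of 1,2-dihydroxyethyl on a saturated chain carbon bound to an aromatic nitrogen gives a number 4 percentage points lower from compound 1 to compound 3 (within the scatter) as the first step that can be read at this place. Both groups count 4 heavy atoms, while 2 hydrogen-bond donors and 2 hydrogen-bond acceptors give way to 1 of each, with the two compounds within the scatter of each other. No available evidence bears on this result.

As far as these compounds go, whether an amine, a carboxylic acid or a longer chain at this place would give a number beyond the scatter from compound 1 stays open.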